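Trading a Basic Side Chain for a Methoxy Group

The source may hold more compounds than are shown below. What is called first, only, known or untested is meant among the compounds shown, and "the series" means these compounds.

Measured so far:
Compound 1, `Cc1ccc(-c2cn(-c3ccc(CN4CCN(C)CC4)cc3)nn2)cc1Nc1nccc(-c2cccnc2)n1`: 4700 nM
Compound 2, `Cc1ccc(-c2cn(-c3ccc(CN4CCCC4)cc3)nn2)cc1Nc1nccc(-c2cccnc2)n1`: 3890 nM

Both compounds share one core and differ only in the ring attached to a saturated chain carbon on the outer phenyl ring. In a functional assay on K562 cells (Homo sapiens) for inhibition, read by MTT assay, with a stated time of 72 h (on this read-out higher numbers stand for weaker inhibition and lower numbers for stronger inhibition), compound 1 gives 4700 nM and compound 2 gives 3890 nM. Going by the values given here, the single step between them, a 1.2-fold lower number from compound 1 to compound 2 (0.08 log units; within the scatter), shows that exchanging one saturated nitrogen ring for another made no difference that can be told apart from repeat-measurement noise. Compound 2 therefore sits alongside compound 1, with the gap between them inside the scatter.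

Compound 3, `COc1ccc(-n2cc(-c3ccc(C)c(Nc4nccc(-c5cccnc5)n4)c3)nn2)cc1`, takes a further step: methoxy in place of (pyrrolidin-1-yl)methyl on an aromatic carbon. Among the compounds with values here, the only step measured so far, a 1.2-fold lower number from compound 1 to compound 2 (0.08 log units; within the scatter), kept a ring-bearing side chain in place and merely varied it; no measured pair shows what happens when that whole side chain is removed. Within the data shown here, the one precedent was flat, so the step from compound 2 to compound 3 is expected to be modest, a 1.4-fold higher number from compound 2 to compound 3 (0.15 log units; within the scatter), and is estimated to stay near the scatter. Compound 3 is expected to give about 5500 nM, with a range from 1500 nM to 20000 nM.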

Compound 3, half-maximal inhibitory concentration: > 30000 nM
Compound 3: only a limit was reported; the forecaster's own chance of this, stated with the estimate: 10%; middle value at least 5.4-fold (0.73 log units) from the limit.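

Compound 3 shows that this aromatic carbon is not indifferent to what it carries, which the flat step between compounds 1 and 2 could not reveal. In this assay, replacing the whole side chain with methoxy gives an at least 7.7-fold higher number from compound 2 to compound 3 (0.88 log units; beyond the scatter), and the comparison with the piperazine-bearing side chain gives an at least 6.3-fold higher number from compound 1 to compound 3 (0.80 log units; beyond the scatter), so exchanging one saturated nitrogen ring for another changes little, while losing the side chain altogether costs a great deal. The result for compound 3 is a limit of the assay and not a number, so both steps give only a minimum size: the limit of > 30000 nM in this assay, at which 1 of the 3 values shown sits.

The compounds shown leave open which part of the side chain matters, since methoxy removes the ring, the chain carbon and the nitrogen all at once, and a (dimethylamino)methyl group, which keeps the nitrogen without a ring, or a cyclopentylmethyl group, which keeps a ring without the nitrogen, would help to pull these apart. On these data alone, how much activity, if any, compound 3 retains at higher concentrations also remains unknown.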